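The source may hold more compounds than are shown below. What is called first, only, known or untested is meant among the compounds shown, and "the series" means these compounds.

Two compounds of the series carry results in a functional assay on HeLa S3 cells (Homo sapiens) for antiproliferative activity, read by XTT assay, with a stated time of 72 h; on this read-out lower numbers stand for stronger inhibition and higher numbers for weaker inhibition. Compound 1 `COc1ncnc2c1c(-c1ccccc1)cn2[C@@H]1O[C@H](CO)[C@@H](O)[C@H]1O` is reported only as a limit of the assay: in this assay compound 1 gives > 20000 nM. Compound 2 `COc1ncnc2c1c(I)cn2[C@@H]1O[C@H](CO)[C@@H](O)[C@H]1O` in this assay gives 14300 nM, the only number shown; set against that limit this is an at least 1.3-fold lower number from compound 1 to compound 2 (0.14 log units; that floor lies within the scatter), so compound 2 cannot be ranked against compound 1 on the numbers shown (the limit of > 20000 nM in this assay, at which 1 of the 2 values shown sits). Compound 3 `COc1ncnc2c1c(-c1ccco1)cn2[C@@H]1O[C@H](CO)[C@@H](O)[C@H]1O` differs from compound 2 by furan-2-yl in place of iodo on an aromatic carbon. Among the measured compounds shown here, the single measured step that bears on it is the one from phenyl to iodo, whose size sits inside the scatter at the floor; replacing iodo with a five-membered aromatic group returns to an aryl substituent as in compound 1, so no step beyond the scatter is expected, and a limit may again be reported. Compound 3 is therefore estimated at 25000 nM, within 8000 nM to 80000 nM, an expected step of a 1.7-fold higher number from compound 2 to compound 3 (0.24 log units; within the scatter).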

Compound 3, half-maximal inhibitory concentration: 1020 nM
Compound 3: middle estimate off by 25-fold (1.39 log units), on the high side; the whole stated range lies above it.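

At this aromatic carbon, two ring bonds from the ring nitrogen, the substituent can shift this assay well beyond the scatter: furan-2-yl in place of iodo gives a 14-fold lower number from compound 2 to compound 3 (1.15 log units; beyond the scatter). Furan-2-yl in place of phenyl gives an at least 19-fold lower number from compound 1 to compound 3 (1.29 log units; beyond the scatter), so carrying an aromatic ring at this place does not by itself fix the read-out, and the five-membered ring with its hetero atom parts from the phenyl group. That second step is only a floor, as compound 1 stands at a limit of the assay: the limit of > 20000 nM in this assay, at which 1 of the 3 values shown sits.

The compounds shown leave open whether the lower number goes with the ring oxygen, with the ring size, or with the point of attachment. Thiophen-2-yl, with sulfur in place of the oxygen, and furan-3-yl would separate these readings.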